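The compounds below may be only part of what the source reports. "The series", "measured", "known", "first", "only" and "open" are said of these compounds alone.

Working notes on the series. Compound 1 `CC(=O)Nc1cc2c(C3CCN(C)CC3)c[nH]c2cn1` carries an acetyl on the amide nitrogen of the shared core and, in an assay for binding affinity to 5-hydroxytryptamine receptor 1F (Homo sapiens), read by radioligand binding (a higher number here means a weaker inhibitor, a lower number a stronger inhibitor), compound 1 gives 210 nM. Compound 2 `CN1CCC(c2c[nH]c3ccc(NC(=O)C4CCCCC4)nc23)CC1` carries a cyclohexyl carbonyl instead and in this assay compound 2 gives 20 nM. Compound 3 `CN1CCC(c2c[nH]c3ccc(NC(=O)c4cccc(F)c4)nc23)CC1` carries a 3-fluorophenyl carbonyl and in this assay compound 3 gives 11 nM, the lowest of the three numbers; the step of a 1.8-fold lower number from compound 2 to compound 3 (0.26 log units; within the scatter) is within the scatter, while compound 1 sits far higher.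

Compound 4 `CN1CCC(c2c[nH]c3ccc(NC(=O)c4ccncc4)nc23)CC1` is not yet measured. The change from compound 3 is pyridin-4-yl in place of 3-fluorophenyl on a carbonyl carbon. Going by the values given here, the only measured step touching the carbonyl substituent, a 1.8-fold lower number from compound 2 to compound 3 (0.26 log units; within the scatter), shows that a six-membered ring carrying a carbonyl, whether aromatic or not, gives a number close to that of compound 3. Among the compounds with values here, no measured step bears on a ring nitrogen in this position. The expectation for compound 4 is therefore a step of a 1.4-fold higher number from compound 3 to compound 4 (0.13 log units; within the scatter), not beyond the scatter. Compound 4 is estimated at 15 nM, with a range from 5 nM to 45 nM.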

Compound 4, inhibition constant: 8.4 nM
Beside the measured number, compound 4's estimate is 1.8-fold (0.25 log units) above it; low and high end bracket the measured number.
By their numbers in this assay, from the lowest: compounds 4, 3 and 2 (each within the scatter of the next, the first and the last beyond it); then compound 1.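

On the carbonyl carbon, pyridin-4-yl brings a ring nitrogen into this position, and in this assay the step of a 1.3-fold lower number from compound 3 to compound 4 (0.12 log units; within the scatter) shows that this exchange for 3-fluorophenyl is tolerated without a change beyond the scatter. Measured against cyclohexyl, the step of a 2.4-fold lower number from compound 2 to compound 4 (0.38 log units; beyond the scatter) is modest but is the first among these aromatic and non-aromatic ring amides to pass beyond the scatter, whereas a 1.8-fold lower number from compound 2 to compound 3 (0.26 log units; within the scatter) did not. No measurement shown here explains either step.

The compounds shown leave open whether the ring nitrogen must sit as it does in pyridin-4-yl, since pyridin-3-yl and pyridin-2-yl do not appear among them. They also leave open how this assay would read for unsubstituted phenyl, for a five-membered ring such as thiophene, or for a phenyl ring carrying an amine or a carboxylic acid.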